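A few compounds are considered here, and "the series" means these few. Any claim that something is new, unique, unknown or untested is made for them only; others in the source may bear on it.

Working notes on the series.

Of the compounds shown here, three carry numbers so far in an assay on HEK293F cells for inhibition of cholesterol 24-hydroxylase (Homo sapiens), read by trypan blue exclusion, with stated times of 15 min and 5 h; a higher number here means a weaker inhibitor, a lower number a stronger inhibitor. Compound 1 `O=C(NC1CC1)N1CCN(c2cnccc2-c2ccccc2)CC1` gives 52 nM in this assay. Compound 2 `O=C(NC1CC1)c1ccc(-c2cnccc2-c2ccccc2)cc1` gives 74 nM in this assay. Compound 3 `CNC(=O)C1CCN(c2cncnc2-c2ccccc2)CC1` gives 72 nM in this assay. Compound 3 thus stands second highest of the three numbers, but its gap to compound 2 and its gap to compound 1 both lie within the usual scatter, so the three cannot be ordered against one another on these numbers alone.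

The next compound is compound 4 `O=C(Nc1ccccc1)C1CCN(c2cncnc2-c2ccccc2)CC1`, which differs from compound 3 in one place: phenyl in place of methyl on an amide-type nitrogen. Going by the values given here, no pair among the measured compounds shows this change, so there is nothing itself to size it from. The expectation is therefore a small step, in the direction of a somewhat higher number, of roughly a 1.5-fold higher number from compound 3 to compound 4 (0.18 log units; within the scatter), though a result inside the scatter would be no surprise. The estimate for compound 4 in this assay is 110 nM, with a range from 35 nM to 350 nM.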

Compound 4, half-maximal inhibitory concentration: 28 nM
Estimate against measurement, compound 4: 3.9-fold (0.59 log units) above; the measured number lies below the stated range.
By their numbers in this assay, from the lowest: compounds 4, 1, 3 and 2 (each within the scatter of the next, the first and the last beyond it).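

In this assay, phenyl in place of methyl on the amide-type nitrogen gives a 2.6-fold lower number from compound 3 to compound 4 (0.41 log units; beyond the scatter), a modest step. Going by these compounds alone, it is the first step that can be read at all, and it shows that this position accepts a six-membered aromatic ring of carbon only, with the number going down rather than up. Nothing at hand explains this step.

A single step from methyl cannot show whether the lower number goes with the aromatic ring itself or with the larger carbon group, which ethyl, cyclohexyl or benzyl on the same nitrogen could separate. Also open, going by these compounds, is how a phenyl ring bearing a fluorine or a methoxy group, or a pyridine ring in its place, would read.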